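Swapping chloro for methoxy on a nitrothiazole amide

The source may report more compounds than this note shows. Statements on the series, on what has been measured and on what is new or still open speak of the compounds shown alone.

For the measured compounds named here, compound 1 `O=C(Nc1ncc([N+](=O)[O-])s1)c1cc(Cl)ccc1O` gives 63% in an ADME assay on HEK-293T cells (Homo sapiens) for cytotoxicity, read by MTT assay, tested at 100 uM (a lower number here means a stronger effect, a higher number a weaker effect of the compound at the concentration tested), the higher of the two numbers measured so far. Going by the values given here, compound 2 `CC(=O)Oc1ccc(Cl)cc1C(=O)Nc1ncc([N+](=O)[O-])s1` gives 31.2%, and the only measured step, a number 31.8 percentage points lower from compound 1 to compound 2 (beyond the scatter), concerns an acetyl replacing a hydrogen, not the change studied here. Compound 3 `COc1ccc(O)c(C(=O)Nc2ncc([N+](=O)[O-])s2)c1` differs from compound 1 by methoxy in place of chloro on an aromatic carbon. Among the compounds with values here, no measured step bears on this change, so no shift beyond the scatter is expected, a step of a number 3 percentage points lower from compound 1 to compound 3 (within the scatter). Compound 3 is therefore estimated at 60%, within 38% to 85%.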

Compound 3, a percentage reported as activity, at one concentration (the size of the read-out at that concentration, not a potency): 100%
Compound 3: the middle estimate sits 40 percentage points below what was measured, and the stated range ends below it.
By their numbers in this assay, from the lowest: compound 2; then compound 1; then compound 3.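

At this carbon, para to a hydroxy group, the substituent clearly matters: in this assay methoxy in place of chloro gives a number 37 percentage points higher from compound 1 to compound 3 (beyond the scatter) and so a weaker effect at the concentration tested. The earlier step changed only the hydroxy oxygen, so it said nothing about this ring carbon. Nothing available explains the shift.

Going by these compounds, whether losing chloro or gaining methoxy drives the step remains open, and a plain hydrogen or an amine at this carbon would help separate the two. Also open, on these data alone, is whether acetyl on the oxygen would lower the number with methoxy present, as it does with chloro.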